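Hydroxy-bearing benzyl in place of dichlorobenzyl on adenosine core

A few compounds are considered here, and "the series" means these few. Any claim that something is new, unique, unknown or untested is made for them only; others in the source may bear on it.

Measured compounds:
- compound 1, `OC[C@H]1O[C@@H](n2cnc3c(NCc4ccc(Cl)cc4Cl)ncnc32)[C@H](O)[C@@H]1O`: 127000 nM
- compound 2, `COc1ccc(CNc2ncnc3c2ncn3C2OC(CO)[C@@H](O)[C@H]2O)c(O)c1`: 2200 nM
- compound 3, `COc1cc(O)cc(OC)c1CNc1ncnc2c1ncn2[C@@H]1O[C@H](CO)[C@@H](O)[C@H]1O`: a limit, > 166000 nM

In a functional assay on MCF cells (Homo sapiens) for antiproliferative activity, with a stated time of 72 h (on this read-out higher numbers stand for weaker inhibition and lower numbers for stronger inhibition), compound 1 gives 127000 nM, the highest of the two numbers shown. Compound 2 gives 2200 nM, a much lower number, beyond the usual scatter. For compound 3 the assay reports only a limit, > 166000 nM, and so no number (the limit of > 166000 nM in this assay, at which 1 of the 3 values shown sits).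

Compound 4, `Cc1ccc(O)c(CNc2ncnc3c2ncn3[C@@H]2O[C@H](CO)[C@@H](O)[C@H]2O)c1`, has not been measured. It differs from compound 1 in one place: 2-hydroxy-5-methylphenyl in place of 2,4-dichlorophenyl on a saturated chain carbon bound to a nitrogen on an aromatic ring. Going by the values given here, no two measured compounds differ in a single place, so no measured step guides this change directly. Compound 2, which likewise carries a hydroxy on its benzyl ring, gives 2200 nM, while compound 1 gives 127000 nM. On that basis compound 4 is expected to sit well below compound 1, with the step of a 21-fold lower number from compound 1 to compound 4 (1.33 log units; beyond the scatter) estimated as a clear drop beyond the scatter. Compound 4 is estimated at 6000 nM, within 1500 nM to 40000 nM.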

Compound 4, half-maximal inhibitory concentration: > 166000 nM
Compound 4: no number, only a limit (the forecaster's own chance of this, stated with the estimate: 10%); at least 27-fold (1.44 log units) between middle value and limit.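

In this assay, going by these compounds alone, the swap of 2,4-dichlorophenyl for 2-hydroxy-5-methylphenyl on a saturated chain carbon bound to a nitrogen on an aromatic ring is the first single change that can be read, and it gives an at least 1.3-fold higher number from compound 1 to compound 4 (0.11 log units; that floor lies within the scatter). Going by these compounds, this swap therefore brings no lower number on the shared core, although its true size stays open and it cannot be called a clear rise. Compound 4 gives a limit rather than a number, and compound 3 is the other compound at that limit: the limit of > 166000 nM in this assay, at which 2 of the 4 values shown sit.

The hydroxy and the methyl enter together, so the compounds shown do not separate what each one does at this position. On these data alone, it also remains open how this position would respond to an amine or a carboxylic acid on the ring, or to a longer chain in place of the methyl.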